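Methyl in place of hydrogen on the aromatic ring

The compounds below may be only part of what the source reports. "The series", "measured", "known", "first", "only" and "open" are said of these compounds alone.

Two compounds of this series carry a measurement. Compound 1 `N/C(=N\NC(=S)N1CCCCCC1)c1ccccn1` gives 2600 nM in a functional assay on MCF7 cells (Homo sapiens) for cytotoxicity, read by MTT assay, with a stated time of 72 h; on this read-out lower numbers stand for stronger inhibition and higher numbers for weaker inhibition. Compound 2 `N/C(=N\NC(=S)N1CCOCC1)c1ccccn1` gives 4700 nM in this assay, the highest of the two numbers, though the gap to compound 1 lies within the scatter. Compound 3 `Cc1ccnc(/C(N)=N/NC(=S)N2CCOCC2)c1` is not yet measured; it differs from compound 2 by methyl in place of hydrogen on an aromatic carbon, a methyl in place of hydrogen on an aromatic carbon. Within the data shown here, no measured pair isolates this change. The step of a 1.2-fold lower number from compound 2 to compound 3 (0.07 log units; within the scatter) is expected to stay within the scatter, with no clear direction. Compound 3 is estimated at 4000 nM, in a range of 1500 nM to 11000 nM.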

Compound 3, half-maximal inhibitory concentration: > 100000 nM
Compound 3: a limit, no number; the forecaster's own chance of this, stated with the estimate: 5%; middle value at least 25-fold (1.39 log units) away from the limit.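

Methyl in place of hydrogen on an aromatic carbon, opposite the ring nitrogen, gives an at least 21-fold higher number from compound 2 to compound 3 (1.32 log units; beyond the scatter) in this assay. Among these compounds, compound 1 and compound 2, which differ in another place, stay within the scatter of each other, so this aromatic position is the first place where a change moves the number beyond the scatter. The value of compound 3 is a limit of the assay, not a number: the limit of > 100000 nM in this assay, at which 1 of the 3 values shown sits.

On these data alone, whether a fluorine, a methoxy or an amine at this position would give a step of the same kind remains open. So does whether methyl gives the same step on the core of compound 1.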